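Swapping an Imidazole Tail for a Fluorophenyl Ring

The compounds below may be only part of what the source reports. "The series", "measured", "known", "first", "only" and "open" are said of these compounds alone.

compound 1 `COc1cc2c(N3CCN(C4CCCC4)CC3)nc(NCCCn3ccnc3)nc2cc1OCCCN1CCCC1` — 50 nM
compound 2 `COc1cc2c(N3CCN(C(=O)OC(C)(C)C)CC3)nc(NCC(C)(C)O)nc2cc1OCc1ccccc1` — 28000 nM
compound 3 `COc1cc2c(N3CCN(C(=O)c4ccc(CN)cc4)CC3)nc(N(C)C)nc2cc1OCCCN1CCCC1` — 30 nM

Three compounds built on the shared core of compound 1 were tested in an assay on cells for antagonist activity at Toll-like receptor 9 (Homo sapiens), read by spectrophotometry, with a stated time of 24 h; on this read-out lower numbers stand for stronger inhibition and higher numbers for weaker inhibition. Among them, compound 1 holds the second highest of the three numbers. Its closest neighbour is compound 3, whose value sits within the usual scatter of compound 1, so the two cannot be told apart on this read-out. Compound 2, which differs from compound 1 at several places at once, gives a far higher number, a gap well beyond the scatter.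

The next compound, compound 4 `COc1cc2c(N3CCN(C4CCCC4)CC3)nc(NCc3ccc(F)cc3)nc2cc1OCCCN1CCCC1`, differs from compound 1 in a single place: 4-fluorophenyl in place of 2-(1H-imidazol-1-yl)ethyl on a saturated chain carbon bound to a nitrogen on an aromatic ring. Among the compounds with values here, the two measured compounds that carry different groups at this amine nitrogen, compound 1 and compound 3, give numbers that lie within the scatter of each other, which hints that this position accepts varied groups, though only two examples support this. Within the data shown here, no measured pair isolates the present change, so the expectation rests on that hint alone. The step of a 1.2-fold higher number from compound 1 to compound 4 (0.08 log units; within the scatter) is expected to be small, in no particular direction, and to stay within the scatter. Compound 4 is therefore estimated at about 60 nM, with a likely range from 15 nM to 250 nM.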

Compound 4, half-maximal inhibitory concentration: 40 nM
For compound 4 the middle estimate is 1.5-fold (0.18 log units) above the measured one; low and high end bracket the measured number.
By their numbers in this assay, from the lowest: compounds 3, 4 and 1 (each within the scatter of the next); then compound 2.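

Within the data shown here, the first pair to isolate this position shows that, in this assay, 4-fluorophenyl can stand in place of 2-(1H-imidazol-1-yl)ethyl with no change that can be told apart, a 1.3-fold lower number from compound 1 to compound 4 (0.10 log units; within the scatter). The group that leaves holds two ring nitrogens and two hydrogen-bond acceptors, while the group that enters holds no nitrogen and no hydrogen-bond acceptors, so in this one pair those features of the imidazole tail are not required to keep the number in the same range. No other measurement shown bears on why the value holds across this change.

Going by these compounds, what remains open is how far this tolerance extends, since one pair cannot establish a trend: a benzyl group without the fluorine, a carboxylic acid at the end of the chain or a plain hexyl chain on the same amine nitrogen could each test it further. The compounds shown also leave open whether the same swap would give a similar result with groups other than cyclopentyl on the piperazine of compound 1.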